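This account rests on a few compounds, and the source may have more. Where it says the series, first, only, none or still open, it means among the compounds named here.

Measured compounds in an assay on CHO cells for displacement of a labelled ligand from transient receptor potential cation channel subfamily V member 1 (Homo sapiens), read by scintillation counting, with a stated time of 60 min; a higher number here means a weaker inhibitor, a lower number a stronger inhibitor:
compound 1 `CC(C(=O)NCc1ccc(C(F)(F)F)nc1N(Cc1ccccc1)S(C)(=O)=O)c1ccc(NS(C)(=O)=O)c(F)c1`, compound 1 gives 101 nM
compound 2 `CC(C(=O)NCc1ccc(C(F)(F)F)nc1N(Cc1ccccc1)S(=O)(=O)C(C)C)c1ccc(NS(C)(=O)=O)c(F)c1`, compound 2 gives 18.1 nM
compound 3 `CC(C(=O)NCc1ccc(C(F)(F)F)nc1N(Cc1ccccc1)S(=O)(=O)c1ccc(F)cc1)c1ccc(NS(C)(=O)=O)c(F)c1`, compound 3 gives 1.56 nM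

The three share one core and differ only in the group on the sulfonyl sulfur attached to the ring nitrogen. Every change there moved the number beyond the scatter: a 5.6-fold lower number from compound 1 to compound 2 (0.75 log units; beyond the scatter), a 12-fold lower number from compound 2 to compound 3 (1.06 log units; beyond the scatter), and overall a 65-fold lower number from compound 1 to compound 3 (1.81 log units; beyond the scatter). Compound 3 therefore stands lowest of the three in this assay, and both steps to the other two are beyond the scatter.

Compound 4 `CC(C(=O)NCc1ccc(C(F)(F)F)nc1N(Cc1ccc(Cl)cc1)S(=O)(=O)c1ccc(F)cc1)c1ccc(NS(C)(=O)=O)c(F)c1` keeps the 4-fluorophenyl sulfonyl group of compound 3 and changes the benzyl group instead: chloro in place of hydrogen on an aromatic carbon. For the measured compounds named here, none of the measured steps bears on this position; all three concern the sulfonyl substituent, and the benzyl group is unchanged across compounds 1, 2 and 3. Going by the values given here, there is thus nothing among the measured compounds to set a direction for this step. The expectation for compound 4 is a step of a 1.0-fold higher number from compound 3 to compound 4 (0.01 log units; within the scatter), within the scatter, in this assay. Compound 4 is estimated at 1.6 nM, with a range of 0.5 nM to 5 nM.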

Compound 4, inhibition constant: 0.9 nM
Compound 4: the middle estimate sits 1.8-fold (0.25 log units) above what was measured; the range from low to high includes it.
By their numbers in this assay, from the lowest: compounds 4 and 3 (each within the scatter of the next); then compound 2; then compound 1.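

In this assay, for the compounds shown here, the benzyl group is varied here for the first time, and 4-chlorobenzyl in place of benzyl gives a 1.7-fold lower number from compound 3 to compound 4 (0.24 log units; within the scatter) on the 4-fluorophenyl sulfonyl background. The aromatic carbon para to a large group therefore carries a chloro with compound 4 not separable from compound 3 in this assay, in contrast to the sulfonyl substituent, where a single change gave a 12-fold lower number from compound 2 to compound 3 (1.06 log units; beyond the scatter) and so moved the number beyond the scatter. No supporting data are available that bear on this result.

Open, as far as these compounds go, is whether the chloro step stays within the scatter when the sulfonyl group is methyl or isopropyl rather than 4-fluorophenyl, since the step is read on one background only. Also open, from the compounds shown here alone, is how the same place on the benzyl ring responds to other groups, such as an amine, a carboxylic acid or a longer alkyl chain, which would show whether this place tolerates more than a single chlorine atom.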